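Chloro on the Fused Ring and Microsomal Stability

A few compounds are considered here, and "the series" means these few. Any claim that something is new, unique, unknown or untested is made for them only; others in the source may bear on it.

Measured compounds:
Compound 1 `CCn1c(=O)/c(=C2\Sc3ccccc3N2C)s/c1=C\c1ccncc1` gives 6% in an ADME assay on microsomes from liver (Mus musculus) for metabolic stability, with a stated time of 30 min; on this read-out higher numbers stand for a more stable compound and lower numbers for a less stable compound.
Compound 2 `CCn1c(=O)/c(=C2\Sc3ccc(F)cc3N2C)s/c1=C\c1ccncc1` gives 23% in this assay.
Compound 3 `CCn1c(=O)/c(=C2\Sc3cccc(Cl)c3N2C)s/c1=C\c1ccncc1` gives "nd(insoluble)" (no result reported) in this assay, so no number was reported for it.

Among the measured compounds shown here, compound 1 stands lowest of the two numbers; the only measured step, a number 17 percentage points higher from compound 1 to compound 2 (beyond the scatter), came with fluoro in place of hydrogen on an aromatic carbon. Compound 4 `CCn1c(=O)/c(=C2\Sc3cc(Cl)ccc3N2C)s/c1=C\c1ccncc1` differs from compound 1 by chloro in place of hydrogen on an aromatic carbon. For the measured compounds named here, the one step that bears on this change is the halogen entry from compound 1 to compound 2, which was modest and upward and beyond the scatter. Compound 3, carrying chloro at another place, contributes no number. Compound 4 is therefore expected to move modestly upward, a number 9 percentage points higher from compound 1 to compound 4 (within the scatter). For compound 4 the estimate is 15%, within a range from 3% to 35%.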

Compound 4, percent of the compound remaining: 39%
The estimate for compound 4 lay 24 percentage points below the measured number, outside the stated range (above it).
By their numbers in this assay, from the lowest: compound 1; then compound 2; then compound 4.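

In this assay, chloro on an aromatic carbon of the six-membered aromatic ring of carbon only goes with a number 33 percentage points higher from compound 1 to compound 4 (beyond the scatter), a large step, whereas fluoro went with a number 17 percentage points higher from compound 1 to compound 2 (beyond the scatter), a modest one. Among the compounds shown here, compound 4 also gives the first number for a chloro, as compound 3 has none. Nothing shown here explains the rise.

The compounds shown leave open what chloro at other places on this ring would give, and whether a methoxy group or an amine at this position would match chloro.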